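Swapping an aminotriazole for a methyl-oxadiazole on the sulfur

This account rests on a few compounds, and the source may have more. Where it says the series, first, only, none or still open, it means among the compounds named here.

Measured compounds:
- compound 1, `O=c1c(CSc2cc(=O)c3ccccc3s2)coc2ccccc12`: 2600 nM
- compound 2, `Cc1nnc(SCc2coc3ccc(Cl)cc3c2=O)o1`: 3200 nM
- compound 3, `Nc1nc(SCc2coc3ccccc3c2=O)n[nH]1`: > 25000 nM

Three compounds that share a core carrying a sulfur-linked side group have been tested in a functional assay on HeLa cells (Homo sapiens) for cytotoxicity, read by MTT assay, with a stated time of 72 h; on this read-out lower numbers stand for stronger inhibition and higher numbers for weaker inhibition. Compound 1 gives 2600 nM, and compound 2 gives 3200 nM. Compound 3 stands apart: its result of > 25000 nM is a limit of the assay rather than a number, as the limit of > 25000 nM in this assay, at which 1 of the 3 values shown sits, records, so only an upper boundary of its activity is known.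

Compound 4, `Cc1nnc(SCc2coc3ccccc3c2=O)o1`, has not yet been measured. It differs from compound 3 in a single place: 5-methyl-1,3,4-oxadiazol-2-yl in place of 5-amino-1H-1,2,4-triazol-3-yl on a sulfur. For the measured compounds named here, with only a limit for compound 3, no step between measured compounds is available to anchor the change.

The expectation is that the step from compound 3 to compound 4 amounts to an at least 5.0-fold lower number from compound 3 to compound 4 (0.69 log units; beyond the scatter) in this assay, towards stronger inhibition and beyond the usual scatter. This rests on compound 2, which also bears a 5-methyl-1,3,4-oxadiazol-2-yl group and gives 3200 nM. Compound 4 is therefore estimated at 5000 nM in this assay, within a range from 1500 nM to 20000 nM.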

Compound 4, half-maximal inhibitory concentration: 1400 nM
The estimate for compound 4 lay 3.6-fold (0.55 log units) above the measured number; measured number outside the range, below it.
By their numbers in this assay, from the lowest: compounds 4, 1 and 2 (each within the scatter of the next, the first and the last beyond it). At a limit, above all of these: compound 3.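

Compound 3 has no true number, only a limit of the assay: the limit of > 25000 nM in this assay, at which 1 of the 4 values shown sits. Even so, replacing 5-amino-1H-1,2,4-triazol-3-yl with 5-methyl-1,3,4-oxadiazol-2-yl on the sulfur now has a measured minimum size in this assay, an at least 17-fold lower number from compound 3 to compound 4 (1.25 log units; beyond the scatter), so the group on the sulfur clearly matters for this read-out. For the compounds shown here, a second, modest effect also appears for the first time, as hydrogen in place of chloro on an aromatic carbon gives a 2.3-fold lower number from compound 2 to compound 4 (0.36 log units; beyond the scatter).

The swap on the sulfur changes the ring and its substituent together, so the compounds shown cannot separate the two, and a 5-amino-1,3,4-oxadiazol-2-yl group would help to pull them apart. From the compounds shown here alone, it also remains open how fluoro or methoxy would compare with hydrogen and chloro on that aromatic carbon.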